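Swapping Methoxy for Fluoro on the Central Aryl Ring

The source may hold more compounds than are shown below. What is called first, only, known or untested is meant among the compounds shown, and "the series" means these compounds.

The two measured compounds share one core. Compound 1 `CCN(c1cc2oc(-c3ccc(F)cc3)c(C(=O)NC)c2cc1-c1cc(F)c(OC)c(C(=O)NC2(c3ncccn3)CC2)c1)S(C)(=O)=O` gives 29 nm/s in an ADME assay on Caco-2 cells (Homo sapiens) for permeability, read by LC-MS, with a stated time of 2 h, tested at 3 uM (a higher number here means that the compound crosses the layer faster, a lower number that the compound crosses the layer more slowly), and compound 2 `CCN(c1cc2oc(-c3ccc(F)cc3)c(C(=O)NC)c2cc1-c1cc(C)c(OC)c(C(=O)NC2(c3ncccn3)CC2)c1)S(C)(=O)=O` gives 33 nm/s in this assay; the step of a 1.1-fold higher number from compound 1 to compound 2 (0.06 log units; within the scatter) shows that these two numbers cannot be told apart. Compound 3 `CCN(c1cc2oc(-c3ccc(F)cc3)c(C(=O)NC)c2cc1-c1cc(F)c(F)c(C(=O)NC2(c3ncccn3)CC2)c1)S(C)(=O)=O` has not been measured. It differs from compound 1 by fluoro in place of methoxy on an aromatic carbon. For the measured compounds named here, no measured step touches the methoxy group, so the one step that exists, from compound 1 to compound 2, bears on it only indirectly, and that step was within the scatter. With a single aromatic substituent exchanged and the rest of the molecule unchanged, the step in this assay from compound 1 to compound 3 is expected to stay within the scatter, as a 1.2-fold higher number from compound 1 to compound 3 (0.08 log units; within the scatter). Compound 3 is therefore estimated at 35 nm/s, with a range from 17 nm/s to 70 nm/s.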

Compound 3, apparent permeability: 79 nm/s
Compound 3: the middle estimate sits 2.3-fold (0.35 log units) below what was measured; measured number above the stated range.
By their numbers in this assay, from the lowest: compounds 1 and 2 (each within the scatter of the next); then compound 3.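

On the aromatic carbon ortho to a (1-(pyrimidin-2-yl)cyclopropyl)carbamoyl group, fluoro in place of methoxy gives a 2.7-fold higher number from compound 1 to compound 3 (0.44 log units; beyond the scatter) in this assay and so moves the number beyond the scatter. For the compounds shown here, the earlier step, methyl in place of fluoro on a different aromatic carbon, gave only a 1.1-fold higher number from compound 1 to compound 2 (0.06 log units; within the scatter), so of the two aromatic carbons changed so far, only the one that carries methoxy in compound 1 has shifted the number. Nothing available explains why this exchange has that effect.

The compounds shown do not separate what leaving methoxy contributes from what entering fluoro contributes. From the compounds shown here alone, whether the number follows the same direction with hydrogen, chloro, ethoxy or hydroxyl on this carbon remains open, as does whether the exchange gives a similar step on a core carrying methyl in place of the other fluoro.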